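Methyl at a second aromatic carbon of the chromone amide

The compounds below may be only part of what the source reports. "The series", "measured", "known", "first", "only" and "open" are said of these compounds alone.

Measured compounds:
Compound 1 `O=C(Nc1nnn[nH]1)c1cc(=O)c2ccccc2o1`: 100%
Compound 2 `Cc1c(C(=O)Nc2nnn[nH]2)oc2ccccc2c1=O`: 70%

In a functional assay on the whole organism for inhibition, with Rattus norvegicus as the target, with a stated time of 30 min, at a dose of 1 mg/kg by the intravenous route (a lower number here means less inhibition, a higher number more inhibition at the dose given (going by the name of the read-out)), compound 1 gives 100%, the highest of the two numbers; compound 2 gives 70%. Compound 3 `Cc1ccc2oc(C(=O)Nc3nnn[nH]3)cc(=O)c2c1` differs from compound 1 by methyl in place of hydrogen on an aromatic carbon, sitting on a six-membered aromatic ring of carbon only. Among the compounds with values here, the one step that bears on it, a number 30 percentage points lower from compound 1 to compound 2 (beyond the scatter), puts the methyl on a different aromatic carbon, so it is only a loose guide; a modest loss or no change beyond the scatter is expected, a number 15 percentage points lower from compound 1 to compound 3 (beyond the scatter). Compound 3 is therefore estimated at 85%, within 60% to 100%.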

Compound 3, a percentage reported as inhibition, in the whole organism at one dose (the size of the read-out at that dose, not a potency): 75%
For compound 3 the middle estimate is 10 percentage points above the measured one, and the stated range covers the measured number.
By their numbers in this assay, from the lowest: compounds 2 and 3 (each within the scatter of the next); then compound 1.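

On the six-membered aromatic ring of carbon only, methyl in place of hydrogen also lowers inhibition in this assay, giving a number 25 percentage points lower from compound 1 to compound 3 (beyond the scatter), so the loss is not confined to the single aromatic carbon behind a number 30 percentage points lower from compound 1 to compound 2 (beyond the scatter). At both places, then, this small change carries a cost beyond the scatter. No available evidence explains the loss. Still open, from the compounds shown here alone, is whether methoxy, chlorine or a carboxylic acid on this same carbon would fare like methyl, and whether a longer chain would lower inhibition further.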